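The compounds below may be only part of what the source reports. "The series", "measured", "known", "first", "only" and "open" are said of these compounds alone.

Measured so far:
- Compound 1, `Cn1nccc1-c1ccccc1NCC1=NCCN1`, gives 10 nM in an in vitro functional assay on cells (Fibroblast) for agonist activity at Alpha-1A adrenergic receptor (Homo sapiens); on this read-out higher numbers stand for an effect only at larger amounts of compound and lower numbers for an effect already at smaller amounts.
- Compound 3, `CCn1nccc1-c1ccccc1NCC1=NCCN1`, gives 63.1 nM in this assay.
- Compound 2, `CC(C)n1nccc1-c1ccccc1NCC1=NCCN1`, gives only a limit of the assay, < 100000 nM, in this assay.

Compound 1 stands as the lowest of the two real numbers; its nearest neighbour is compound 3, reached by a 6.3-fold higher number from compound 1 to compound 3 (0.80 log units; beyond the scatter). The step from compound 1 to compound 2 is a step that the limit leaves unreadable from compound 1 to compound 2, and that from compound 2 to compound 3 is a step that the limit leaves unreadable from compound 2 to compound 3, both because of the limit of < 100000 nM in this assay, at which 1 of the 3 values shown sits.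

Compound 4, `c1ccc(-c2cn[nH]c2)c(NCC2=NCCN2)c1`, is not yet measured. It differs from compound 1 in one place: 1H-pyrazol-4-yl in place of 1-methyl-1H-pyrazol-5-yl on an aromatic carbon.

Going by the values given here, the one readable step, a 6.3-fold higher number from compound 1 to compound 3 (0.80 log units; beyond the scatter), shows that making the group on the aromatic nitrogen larger costs potency; compound 2, with the still larger isopropyl, only reached a limit. Among the compounds with values here, the change to compound 4 goes the other way, removing the methyl from the aromatic nitrogen altogether, but it also shifts the point at which the ring is attached, and no measured pair speaks to that shift.

The expectation is therefore a small step beyond the scatter, tending to a higher number, a 3.0-fold higher number from compound 1 to compound 4 (0.48 log units; beyond the scatter). Compound 4 is estimated at 30 nM in this assay, expected within 6 nM to 300 nM.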

Compound 4, half-maximal effective concentration: 1.26 nM
Beside the measured number, compound 4's estimate is 24-fold (1.38 log units) above it, and the stated range ends above it.
By their numbers in this assay, from the lowest: compound 4; then compound 1; then compound 3.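

In this assay, putting 1H-pyrazol-4-yl in place of 1-methyl-1H-pyrazol-5-yl on the aromatic carbon gives a 7.9-fold lower number from compound 1 to compound 4 (0.90 log units; beyond the scatter). Going by these compounds alone, the earlier compounds varied only the group on the aromatic nitrogen of the same ring, and their one readable step went to a higher number, so this is the first sign that a change at this position can also lower the number. The change is a bundle, however: the methyl goes, the point of attachment moves, and the count of hydrogen-bond donors goes from 0 to 1, so the single step cannot be divided among these differences, and nothing measured here gives a reason for it.

As far as these compounds go, it remains open how much of the step comes from losing the methyl and how much from moving the attachment point, a question that 1-methyl-1H-pyrazol-4-yl or 1H-pyrazol-5-yl at the same place would help to separate. The steps that involve compound 2 cannot be read, and its value is only a limit of the assay: the limit of < 100000 nM in this assay, at which 1 of the 4 values shown sits.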